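A few compounds are considered here, and "the series" means these few. Any claim that something is new, unique, unknown or untested is made for them only; others in the source may bear on it.

Measured compounds:
- compound 1 `O=S(=O)(NCCCN(c1ccccc1)c1cccc(Cl)c1)c1ccc(C(F)(F)F)cc1`: "not active" (no number reported)
- compound 2 `O=S(=O)(NC1CCC2(OC1)c1ccccc1CCc1ccccc12)c1ccc(OC(F)(F)F)cc1`: 13000 nM

Both compounds were tested in a functional assay on NCI-H1650 cells (Homo sapiens) for inhibition, read by MTT assay, with a stated time of 48 h; a higher number here means a weaker inhibitor of growth, a lower number a stronger inhibitor of growth. Among the compounds with values here, compound 2 holds the only number in this small set, at 13000 nM. Compound 1 is recorded as "not active" (no number reported), with no number, so no step can be read between the two, and compound 2 has nothing numerical to be ranked against.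

Compound 3 `O=S(=O)(NC1CCC2(OC1)c1ccccc1CCc1ccccc12)c1ccc(F)cc1` keeps the core of compound 2 and changes in one place: fluoro in place of trifluoromethoxy on an aromatic carbon. Put another way, 4-(trifluoromethoxy)phenyl becomes 4-fluorophenyl.

Within the data shown here, no measured pair shows what this exchange does in this assay, so the expectation rests on compound 2 at 13000 nM alone. A small move toward weaker growth inhibition is expected, possibly none beyond the scatter. The estimated change is a 1.2-fold higher number from compound 2 to compound 3 (0.09 log units; within the scatter). For compound 3 the expected value is 16000 nM, with an estimated range from 7000 nM to 40000 nM.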

Compound 3, concentration for 50% growth inhibition: 20000 nM
Compound 3: the middle estimate sits 1.3-fold (0.10 log units) below what was measured; measured number inside the range.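

Replacing trifluoromethoxy with fluoro on this aromatic carbon, para to a large group, gives a 1.5-fold higher number from compound 2 to compound 3 (0.19 log units; within the scatter) in this assay. Within the data shown here, this is the first measured pair that isolates this position, and it shows that this exchange does not separate the two compounds: growth inhibition stays the same within the usual scatter even though most of the substituent's heavy atoms are gone. The exchange therefore gives no sign that trifluoromethoxy is needed here for the activity seen with compound 2, and no measurement at hand offers an explanation for this outcome.

The compounds shown leave open whether any group at this place can move the number beyond the scatter, for example an amine or a carboxylic acid on the same aromatic carbon, since two closely matched substituents mark out only a narrow range of what the position might accept. They also leave open whether the same exchange would behave alike on another core, and the step to compound 1 cannot be read, as that compound carries no number.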